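Replacing the amide of compound 1 with a hydroxymethyl-oxadiazole

The source may hold more compounds than are shown below. What is called first, only, known or untested is meant among the compounds shown, and "the series" means these compounds.

Compound 1 `O=C(NCCC1CC1)c1ccc(N2CCC(Oc3ccccc3C(F)(F)F)CC2)nn1` is the strongest inhibitor among the three measured compounds: in an assay on microsomes from liver for inhibition of acyl-CoA desaturase 1 (Rattus norvegicus) (a higher number here means a weaker inhibitor, a lower number a stronger inhibitor), compound 1 gives 14 nM. Compound 2 `c1cn(-c2ccc(N3CCC(Oc4ccc5c(c4)CCC5)CC3)nn2)cn1` gives 62 nM in this assay, and compound 3 `c1cc(OC2CCN(c3ccc(-n4ccnc4)nn3)CC2)c2cc[nH]c2c1` gives 162 nM; the step of a 2.6-fold higher number from compound 2 to compound 3 (0.42 log units; beyond the scatter) concerns the aryl ether side and not the position changed here. Compound 4 `OCc1nnc(-c2ccc(N3CCC(Oc4ccccc4C(F)(F)F)CC3)nn2)o1` differs from compound 1 by 5-(hydroxymethyl)-1,3,4-oxadiazol-2-yl in place of (2-cyclopropylethyl)carbamoyl on an aromatic carbon. Among the measured compounds shown here, no measured step bears on this change, since compounds 2 and 3 differ from compound 1 at two positions at once. The author therefore expects a modest step, estimated as a 2.1-fold higher number from compound 1 to compound 4 (0.33 log units; beyond the scatter), toward a somewhat higher number. For compound 4 the estimate in this assay is 30 nM, with a range from 8 nM to 120 nM.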

Compound 4, half-maximal inhibitory concentration: 2.9 nM
Estimate against measurement, compound 4: 10-fold (1.01 log units) above; measured number below the stated range.
By their numbers in this assay, from the lowest: compound 4; then compound 1; then compound 2; then compound 3.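

In this assay, a 4.8-fold lower number from compound 1 to compound 4 (0.68 log units; beyond the scatter) shows that the (2-cyclopropylethyl)carbamoyl group, with its three-membered ring and amide, is not required at this position on the core of compound 1. A 5-(hydroxymethyl)-1,3,4-oxadiazol-2-yl group is tolerated there and gives the lowest number of the series. Nothing measured here accounts for this difference.

The compounds shown leave open whether the hydroxymethyl group or the oxadiazole ring drives the gain. They also do not show what a methyl group, a carboxylic acid or a longer chain would do in place of the hydroxymethyl.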